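Dimethoxyphenyl isomers at the limit of the cytotoxicity read-out

The source may report more compounds than this note shows. Statements on the series, on what has been measured and on what is new or still open speak of the compounds shown alone.

Going by these compounds, in a functional assay on NCI-H460 cells (Homo sapiens) for cytotoxicity, read by MTT assay, with a stated time of 48 h (on this read-out lower numbers stand for stronger inhibition and higher numbers for weaker inhibition), compound 3 `COc1ccc(OC)c(/C=C/C(=O)/C=C/c2cc3ccccc3nc2Oc2cccc(Cl)c2)c1` gives > 10000 nM as a limit and not as a number, so its true position is unknown. Compound 2 `COc1ccc(/C=C/C(=O)/C=C/c2cc3ccccc3nc2Oc2cccc(Cl)c2)c(OC)c1` gives > 10000 nM as a limit as well. Compound 1 `COc1ccc(/C=C/C(=O)/C=C/c2cc3ccccc3nc2Oc2ccc(Br)cc2)cc1OC` likewise gives > 10000 nM as a limit. Among the compounds with values here, the series therefore stands at the limit of > 10000 nM in this assay, at which 3 of the 3 values shown sit, and no compound in it can be ranked.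

Compound 4 `COc1ccc(/C=C/C(=O)/C=C/c2cc3ccccc3nc2Oc2cccc(Cl)c2)cc1OC` differs from compound 3 by one change on a double-bonded chain carbon bound to a double-bonded chain carbon: 3,4-dimethoxyphenyl in place of 2,5-dimethoxyphenyl on a double-bonded chain carbon bound to a double-bonded chain carbon and the two have the same atoms, joined differently.

Within the data shown here, only one measured step bears on this place, a step that the two limits leave unreadable from compound 2 to compound 3 and it offers neither a size nor a direction to carry over. No step beyond the scatter is therefore expected in this assay on present evidence. The expected change is a step that the limit leaves unreadable from compound 3 to compound 4 and it is a weakly founded estimate. Compound 4 is estimated at 15000 nM with an expected range of 5000 nM to 50000 nM and a report as a limit is the likeliest outcome.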

Compound 4, half-maximal inhibitory concentration: > 10000 nM
Compound 4 ended at the assay's limit; the forecaster's own chance of this, stated with the estimate: 85%; the middle value is on the limit's open side.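

Compound 4 gives > 10000 nM in this assay, a limit and not a number. The steps to it from compound 1, compound 2 and compound 3 therefore cannot be read. Their order and true values remain open, with the whole series at one ceiling: the limit of > 10000 nM in this assay, at which 4 of the 4 values shown sit.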